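Cyclopropyl in place of methoxymethyl: clearance in microsomes

A few compounds are considered here, and "the series" means these few. Any claim that something is new, unique, unknown or untested is made for them only; others in the source may bear on it.

Measured compounds:
Compound 1, `COCc1nc2nc(C)cc(Nc3ccc(S(F)(F)(F)(F)F)cc3)n2n1`: 14.3 mL.min-1.g-1
Compound 2, `COCc1nc2nc(C)cc(Nc3ccc(C(F)(F)F)cc3)n2n1`: 13.3 mL.min-1.g-1
Compound 3, `CCc1nc2nc(C)cc(Nc3cccc(Cl)c3)n2n1`: 125 mL.min-1.g-1

The three compounds were tested in an in vitro ADME assay on microsomes from liver (Mus musculus) for metabolic stability; on this read-out lower numbers stand for slow clearance and higher numbers for fast clearance. Compound 2 gives 13.3 mL.min-1.g-1, and compound 1 gives 14.3 mL.min-1.g-1; the step of a 1.1-fold lower number from compound 1 to compound 2 (0.03 log units; within the scatter) leaves the two within the scatter of each other, so neither can be placed above the other. Compound 3, at 125 mL.min-1.g-1, sits clearly beyond the scatter above both of them, but it differs from compound 2 in two places at once, so its value does not isolate any single change.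

The next compound, compound 4, `Cc1cc(Nc2ccc(C(F)(F)F)cc2)n2nc(C3CC3)nc2n1`, differs from compound 2 in one place: cyclopropyl in place of methoxymethyl on an aromatic carbon. Going by the values given here, no measured step bears on this exchange, since the only step on record, from compound 1 to compound 2, concerns the other end of the molecule and lies within the scatter. The expectation therefore rests on the value of compound 2 alone. Compound 4 is expected to give a number close to that of compound 2, with a step of a 1.7-fold higher number from compound 2 to compound 4 (0.22 log units; within the scatter) that may or may not exceed the scatter. The estimate for compound 4 in this assay is 22 mL.min-1.g-1, with a range from 8 mL.min-1.g-1 to 70 mL.min-1.g-1.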

Compound 4, intrinsic clearance in microsomes: 8.6 mL.min-1.g-1
Estimate against measurement, compound 4: 2.6-fold (0.41 log units) above, and the stated range covers the measured number.
By their numbers in this assay, from the lowest: compounds 4, 2 and 1 (each within the scatter of the next); then compound 3.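

In this assay, going by these compounds alone, the exchange of methoxymethyl for cyclopropyl, on an aromatic carbon of a five-membered aromatic ring with 3 nitrogen, gives a 1.5-fold lower number from compound 2 to compound 4 (0.19 log units; within the scatter), which is the first reading of any change at this position, and it leaves the two compounds inseparable. With the trifluoromethyl end of the molecule held constant, a group with no ring and 1 hydrogen-bond acceptor and a group with one three-membered ring and 0 hydrogen-bond acceptors thus give numbers that cannot be told apart at this place, a statement that rests on this single pair. No measurement at hand speaks to the reason for this outcome.

Going by these compounds, whether the position stays this undemanding for other groups, such as an amine, a carboxylic acid or a longer chain, remains open, as does whether cyclopropyl gives the same reading when the trifluoromethyl group is exchanged for another group. Compound 3, at 125 mL.min-1.g-1, differs from compound 2 in two places at once, so the changes that account for its number also remain open.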